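Methylamino in place of methyl at the shared core

The source may report more compounds than this note shows. Statements on the series, on what has been measured and on what is new or still open speak of the compounds shown alone.

Compound 1: `CNc1nc2c(N)ncnc2n1[C@@H]1O[C@H](CN(C)CCCCON)[C@@H](O)[C@H]1O`, 49 nM
Compound 2: `CN(CCCN)C[C@H]1O[C@@H](n2cnc3c(N)ncnc32)[C@H](O)[C@@H]1O`, 500000 nM
Compound 3: `Cc1nc2c(N)ncnc2n1[C@@H]1O[C@H](CN(C)CCCN)[C@@H](O)[C@H]1O`, 70000 nM

In an assay on isolated protein for inhibition of S-adenosylmethionine decarboxylase proenzyme (Homo sapiens) (on this read-out higher numbers stand for weaker inhibition and lower numbers for stronger inhibition), compound 3 gives 70000 nM, the second highest of the three numbers; its nearest neighbour is compound 2, and a 7.1-fold lower number from compound 2 to compound 3 (0.85 log units; beyond the scatter); compound 1 is the furthest from it, with 49 nM. Compound 4, `CNc1nc2c(N)ncnc2n1[C@@H]1O[C@H](CN(C)CCCN)[C@@H](O)[C@H]1O`, carries methylamino in place of methyl on an aromatic carbon. Among the compounds with values here, no measured pair bears directly on this change: compound 1 holds the same methylamino group but differs also in its chain, so its value can only hint that the methylamino-bearing core sits low on the scale. Within the data shown here, the one measured step, a 7.1-fold lower number from compound 2 to compound 3 (0.85 log units; beyond the scatter), shows that enlarging this position does move the number down. On that basis a further decrease is expected, and compound 4 is estimated at 6000 nM, with a range from 1000 nM to 40000 nM, that is a step of a 12-fold lower number from compound 3 to compound 4 (1.07 log units; beyond the scatter), which is expected to lie beyond the scatter.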

Compound 4, half-maximal inhibitory concentration: 440000 nM
Compound 4: middle estimate off by 73-fold (1.87 log units), on the low side; measured number outside the range, above it.
By their numbers in this assay, from the lowest: compound 1; then compound 3; then compounds 4 and 2 (each within the scatter of the next).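

In this assay, methylamino on this aromatic carbon does not continue the downward move seen with methyl: the direction reverses, with a 6.3-fold higher number from compound 3 to compound 4 (0.80 log units; beyond the scatter). Set against hydrogen at the same carbon, methylamino cannot be told apart from it, with a 1.1-fold lower number from compound 2 to compound 4 (0.06 log units; within the scatter), so among these three groups only methyl separates from the others, and a larger group alone does not bring the number down. With methylamino held in place, a 9000-fold higher number from compound 1 to compound 4 (3.95 log units; beyond the scatter) comes with amino in place of (aminooxy)methyl on a saturated chain carbon, so the low number of compound 1 goes with its chain end and not with the methylamino group.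

Nothing available explains the reversal at this carbon. As far as these compounds go, it remains open how an ethyl group or a chlorine atom would behave there, and whether methyl on the core would combine with the (aminooxy)methyl chain end.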